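Swapping the Amine on the Thiocarbonyl of Compound 1

The source may hold more compounds than are shown below. What is called first, only, known or untested is meant among the compounds shown, and "the series" means these compounds.

This account follows a pair of chromone-derived compounds and an untested relative. In a functional assay on MDA-MB-435S cells (Homo sapiens) for antiproliferative activity, read by MTT assay, with a stated time of 72 h (a higher number here means a weaker inhibitor, a lower number a stronger inhibitor), compound 1 `COc1ccc2oc(CSC(=S)N3CCOCC3)cc(=O)c2c1` gives 3400 nM, the lower of the two numbers recorded, while compound 2 `O=c1c(CSC(=S)N2CCCC2)coc2ccccc12` gives 3800 nM in this assay, a difference that lies within the usual scatter of such measurements, so the two values cannot be ranked against each other.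

Compound 3 `COc1ccc2oc(CSC(=S)N3CCCCC3)cc(=O)c2c1` has not yet been measured. Compared with compound 1, its structure changes in one place: piperidin-1-yl in place of morpholin-4-yl on a thiocarbonyl carbon. Within the data shown here, the two measured compounds offer no direct precedent for this exchange, since no pair among them differs in exactly this way.

Because compound 1 stands at 3400 nM in this assay and the change touches only the ring on the thiocarbonyl carbon, the expected step from compound 1 to compound 3, a 1.1-fold lower number from compound 1 to compound 3 (0.05 log units; within the scatter), is small and is not expected to exceed the scatter in either direction. Compound 3 is therefore expected to give about 3000 nM in this assay, with a likely range from 1200 nM to 7500 nM.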

Compound 3, half-maximal inhibitory concentration: 1500 nM
The estimate for compound 3 lay 2.0-fold (0.30 log units) above the measured number, within the range that was stated.
By their numbers in this assay, from the lowest: compound 3; then compounds 1 and 2 (each within the scatter of the next).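

In this assay, among these compounds, piperidin-1-yl in place of morpholin-4-yl on a thiocarbonyl carbon gives a 2.3-fold lower number from compound 1 to compound 3 (0.36 log units; beyond the scatter), the first step that can be read at this position, modest in size but beyond the scatter. It shows that the ring on the thiocarbonyl carbon is not a silent part of the core of compound 1: the two rings have the same number of heavy atoms and differ in that a ring carbon of piperidin-1-yl stands where morpholin-4-yl has its ring oxygen and its hydrogen-bond acceptor, and this single exchange is enough to move the number. Nothing among the data shown gives a reason for this step.

This single pair leaves open whether the same exchange would give a step of similar size and direction on another core, such as that of compound 2, which carries pyrrolidin-1-yl in this place. It also leaves open how other amines on the thiocarbonyl carbon, such as 4-methylpiperazin-1-yl or diethylamino, would compare with piperidin-1-yl on the core of compound 3.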